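Removing the Methyl from the Nitro-Bearing Ring

The source may hold more compounds than are shown below. What is called first, only, known or untested is meant among the compounds shown, and "the series" means these compounds.

Three compounds share one core. Compound 1 `COC(=O)c1cc(-c2cccc(NC(=O)c3ccc(/C=C/C(=O)c4ccccc4)cc3)c2)on1` carries a phenyl on the carbonyl carbon; compound 2 `COC(=O)c1cc(-c2cccc(NC(=O)c3ccc(/C=C/C(=O)c4ccc(Cl)cc4)cc3)c2)on1` has chloro in place of hydrogen on an aromatic carbon; compound 3 `COC(=O)c1cc(-c2cccc(NC(=O)c3ccc(/C=C/C(=O)c4ccc(C)c([N+](=O)[O-])c4)cc3)c2)on1` has 4-methyl-3-nitrophenyl in place of phenyl on a carbonyl carbon. In an ADME assay on Vero cells (Chlorocebus sabaeus) for cytotoxicity, read by MTT assay, with a stated time of 72 h (on this read-out higher numbers stand for lower toxicity in this test and lower numbers for higher toxicity in this test), compound 1 gives only a limit, > 50 ug/mL. Compound 2 likewise reaches only a limit, > 50 ug/mL. Compound 3 too gives only a limit, > 80 ug/mL. The steps a step that the two limits leave unreadable from compound 1 to compound 2, a step that the two limits leave unreadable from compound 1 to compound 3 and a step that the two limits leave unreadable from compound 2 to compound 3 stay unreadable, as the limit of > 50 ug/mL in this assay, at which 2 of the 3 values shown sit, and the limit of > 80 ug/mL in this assay, at which 1 of the 3 values shown sits, show. Compound 4 `COC(=O)c1cc(-c2cccc(NC(=O)c3ccc(/C=C/C(=O)c4cccc([N+](=O)[O-])c4)cc3)c2)on1` differs from compound 3 by hydrogen in place of methyl on an aromatic carbon. Among the compounds with values here, no measured step reads on this change, so no step beyond the scatter is expected: a number no higher from compound 3 to compound 4 (the limit leaves the size open). Compound 4 is expected near 80 ug/mL, between 40 ug/mL and 160 ug/mL.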

Compound 4, half-maximal cytotoxic concentration: > 40 ug/mL
Compound 4: a limit, no number; the forecaster's own chance of this, stated with the estimate: 80%; the middle value does not contradict the limit.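

Within the data shown here, compound 4 gives only a limit, and compound 1, compound 2 and compound 3 do too, so no step to compound 4 can be read in this assay. The compounds shown leave open whether any of these changes, including the loss of the methyl, alters toxicity to these cells.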